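A few compounds are considered here, and "the series" means these few. Any claim that something is new, unique, unknown or untested is made for them only; others in the source may bear on it.

Working notes on the series. Compound 1 `CCCCCCCCCCCCNc1nc(SCc2ccc(C(F)(F)F)cc2)nc2ccccc12` carries a dodecylamino group on the shared core. In a functional assay on MGC-803 cells (Homo sapiens) for cytotoxicity, read by MTT assay, with a stated time of 72 h (on this read-out higher numbers stand for weaker inhibition and lower numbers for stronger inhibition), compound 1 gives a limit of the assay, > 50000 nM. Compound 2 `FC(F)(F)c1ccc(CSc2nc(N3CCCCC3)c3ccccc3n2)cc1` carries piperidin-1-yl on the same carbon; in this assay compound 2 gives 18600 nM, the only number shown in the set. Compound 3 `FC(F)(F)c1ccc(CSc2nc(Nc3ccccc3Cl)c3ccccc3n2)cc1` carries (2-chlorophenyl)amino in that place. In this assay compound 3 gives a limit, > 50000 nM. For the measured compounds named here, the single measured step is an at least 2.6-fold higher number from compound 2 to compound 3 (0.42 log units; beyond the scatter); its true size is open-ended, being bounded by the limit of > 50000 nM in this assay, at which 2 of the 3 values shown sit.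

Compound 4 `Cc1ccccc1Nc1nc(SCc2ccc(C(F)(F)F)cc2)nc2ccccc12` differs from compound 2 by (2-methylphenyl)amino in place of piperidin-1-yl on an aromatic carbon. Going by the values given here, the change is of the same kind as the one from compound 2 to compound 3, piperidin-1-yl giving way to a substituted phenylamino group in both cases, and that step lost activity beyond the scatter. For compound 4 a step of similar kind and at least similar size is therefore expected, a 3.2-fold higher number from compound 2 to compound 4 (0.51 log units; beyond the scatter), towards weaker inhibition. Compound 4 is expected to give 60000 nM in this assay, with a range from 20000 nM to 200000 nM, and most likely only a limit will be reported.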

Compound 4, half-maximal inhibitory concentration: 24400 nM
Estimate against measurement, compound 4: 2.5-fold (0.39 log units) above, within the range that was stated.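

At this aromatic carbon, next to the ring nitrogen, a phenylamino group can take the place of the saturated ring without a readable change in this assay: (2-methylphenyl)amino in place of piperidin-1-yl gives a 1.3-fold higher number from compound 2 to compound 4 (0.12 log units; within the scatter). The loss seen with compound 3 therefore does not extend to both substituted phenylamino groups shown, and the substituent on the phenyl ring now counts, as methyl in place of chloro gives an at least 2.0-fold lower number from compound 3 to compound 4 (0.31 log units; beyond the scatter). The value of compound 3 is a limit, so this step too is open-ended in size: the limit of > 50000 nM in this assay, at which 2 of the 4 values shown sit.

Going by these compounds, how an unsubstituted phenylamino group, or a methyl on another carbon of the phenyl ring, would compare with the (2-methylphenyl)amino group of compound 4 stays open, and with it whether the chloro and methyl contrast depends on that particular place on the phenyl ring. Also open, on these data alone, is how a morpholin-4-yl ring or a butylamino chain would read at this carbon, the latter being much shorter than the dodecylamino group of compound 1, and whether any group here brings the number clearly below those of compound 2 and compound 4.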